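Swapping the amine on a dithiocarbamate-bearing chromone

A few compounds are considered here, and "the series" means these few. Any claim that something is new, unique, unknown or untested is made for them only; others in the source may bear on it.

Compound 2 `CCOC(=O)c1cc(=O)c2cc(CSC(=S)N(C(C)C)C(C)C)ccc2o1` was tested in a functional assay on MDA-MB-435S cells (Homo sapiens) for antiproliferative activity, read by MTT assay, with a stated time of 72 h (a higher number here means a weaker inhibitor, a lower number a stronger inhibitor), where compound 2 gives 8100 nM. Of the two numbers on record it is the higher one: compound 1 `O=c1c(CSC(=S)N2CCCCC2)coc2cc(Cl)ccc12` gives 240 nM, a gap between compound 1 and compound 2 that is beyond the scatter. Compound 3 `COc1ccc2occ(CSC(=S)N3CCOCC3)c(=O)c2c1` reaches only a limit of the assay, > 40000 nM; this is the limit described by the limit of > 40000 nM in this assay, at which 1 of the 3 values shown sits, and it is not a number. Compound 4 `CCOC(=O)c1cc(=O)c2cc(CSC(=S)N3CCOCC3)ccc2o1` is not yet measured. It differs from compound 2 as follows: morpholin-4-yl in place of diisopropylamino on a thiocarbonyl carbon. Going by the values given here, no measured pair shows this change on its own, so the expected step of a 1.9-fold higher number from compound 2 to compound 4 (0.27 log units; within the scatter) in this assay is a guess that leans toward a weaker result. Compound 4 is estimated at 15000 nM, within a range of 4000 nM to 60000 nM.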

Compound 4, half-maximal inhibitory concentration: > 25000 nM
Compound 4 ended at the assay's limit (the forecaster's own chance of this, stated with the estimate: 30%); at least 1.6-fold (0.22 log units) between middle value and limit.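

Going by these compounds alone, for the first time, two compounds differ only in the amine on the thiocarbonyl carbon, with everything else unchanged. Placing morpholin-4-yl in place of diisopropylamino gives an at least 3.0-fold higher number from compound 2 to compound 4 (0.48 log units; beyond the scatter), so this position clearly affects activity. The true size of the step stays unknown, as compound 4 gives only a limit, not a number, in this assay: the limit of > 25000 nM in this assay, at which 1 of the 4 values shown sits.

Going by these compounds, it remains open whether the ring or its oxygen accounts for the loss. A diethylamino or pyrrolidin-1-yl group on the same carbon would help show how other amines behave here.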